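A few compounds are considered here, and "the series" means these few. Any claim that something is new, unique, unknown or untested is made for them only; others in the source may bear on it.

In a functional assay on Caco-2 cells (Homo sapiens) for antiproliferative activity, read by MTT assay, with a stated time of 48 h (a lower number here means a stronger inhibitor, a higher number a weaker inhibitor), compound 3 (`CCC(C)C(NC(=O)c1ccc(C(CC)(CC)c2ccc(OCCC(O)(CC)CC)c(C)c2)n1CC)C(=O)O`) gives 20000 nM and so holds the higher of the two exact numbers in this small set. Compound 1 (`CCn1c(C(=O)NCCCN(C)C)ccc1C(CC)(CC)c1ccc(OCCC(O)(CC)CC)c(C)c1`) is the nearest at 490 nM and the gap is large (a 41-fold higher number from compound 1 to compound 3 (1.61 log units; beyond the scatter)). Compound 2 (`C#CC(C)OC(=O)c1ccc(C(CC)(CC)c2ccc(OCCC(O)(CC)CC)c(C)c2)n1CC`) gives > 50000 nM as its result, which is a limit and not a number.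

Compound 4 (`CCn1c(C(=O)NC(C)CO)ccc1C(CC)(CC)c1ccc(OCCC(O)(CC)CC)c(C)c1`) differs from compound 3 at a single place (1-(hydroxymethyl)ethyl in place of 1-carboxy-2-methylbutyl on an amide-type nitrogen), with 1-(hydroxymethyl)ethyl in place of 1-carboxy-2-methylbutyl on an amide-type nitrogen. The measured steps that bear on this change what sits on the same carbonyl carbon. One is large (an at least 100-fold higher number from compound 1 to compound 2 (2.00 log units; beyond the scatter)) and one is at least modest (an at least 2.5-fold lower number from compound 2 to compound 3 (0.39 log units; beyond the scatter)). So this place clearly matters, yet no measured compound carries the entering group, and the size of the step remains uncertain. Compound 1 at 490 nM shows that much lower numbers occur with this core, which leaves more room downward than upward. The expected change is modest and toward a lower number (a 3.3-fold lower number from compound 3 to compound 4 (0.52 log units; beyond the scatter)). For compound 4 the estimated value is 6000 nM with an expected range from 1000 nM to 35000 nM in this assay.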

Compound 4, half-maximal inhibitory concentration: > 50000 nM
Compound 4 was reported as a limit; the forecaster's own chance of this, stated with the estimate: 15%; middle value at least 8.3-fold (0.92 log units) away from the limit.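

In this assay, replacing 1-carboxy-2-methylbutyl on the amide-type nitrogen with the smaller 1-(hydroxymethyl)ethyl does not move the result toward that of compound 1; the change gives an at least 2.5-fold higher number from compound 3 to compound 4 (0.39 log units; beyond the scatter). The amide link alone therefore does not bring a low number, and the gap to the 3-(dimethylamino)propyl amide is now an at least 100-fold higher number from compound 1 to compound 4 (2.00 log units; beyond the scatter), leaving compound 1 as the only one of the three amides with a sub-micromolar result. The result for compound 4 is a limit and not a number, and the step to compound 2 cannot be read, since both sit at the same limit: the limit of > 50000 nM in this assay, at which 2 of the 4 values shown sit.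

On these data alone, what remains open is whether compound 1 owes its lower number to the tertiary amine or to the length of its chain. A plain propyl chain without the amine, or a primary amine on the same chain, would help to separate the two.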